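Fluorophenyl variation on the pyridazinone amide series

The source may report more compounds than this note shows. Statements on the series, on what has been measured and on what is new or still open speak of the compounds shown alone.

Measured in a functional assay on A549 cells (Homo sapiens) for cytotoxicity, read by MTT assay, with a stated time of 72 h (a lower number here means a stronger inhibitor, a higher number a weaker inhibitor), so far:
compound 1 `Cc1cc(=O)n(-c2ccc(F)cc2)nc1C(=O)Nc1ccc(Oc2ncnc3ccsc23)cc1` gives 2360 nM
compound 2 `Cc1cc(=O)n(-c2ccccc2C(F)(F)F)nc1C(=O)Nc1ccc(Oc2ncnc3sccc23)cc1` gives 19900 nM
compound 3 `Cc1cc(=O)n(-c2cccc(F)c2)nc1C(=O)Nc1ccc(Oc2ncnc3sccc23)cc1` gives 16400 nM

Compound 3 stands second highest of the three numbers; its nearest neighbour is compound 2, and the two are within the scatter of each other, while compound 1 lies well below both, beyond the scatter. Compound 1 carries the same 4-fluorophenyl as compound 4 but a differently joined core, so its gap to compound 3 cannot be assigned to the aryl group alone.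

Compound 4 `Cc1cc(=O)n(-c2ccc(F)cc2)nc1C(=O)Nc1ccc(Oc2ncnc3sccc23)cc1` has not been measured. It differs from compound 3 as follows: 4-fluorophenyl in place of 3-fluorophenyl on an aromatic nitrogen. Within the data shown here, the only measured step that speaks to such a change is a 1.2-fold lower number from compound 2 to compound 3 (0.08 log units; within the scatter), a swap of one aryl group on the same nitrogen that stayed within the scatter. Against that, the pair compound 1 and compound 3 shows that a 4-fluorophenyl compound can sit far lower, though the core differs there too. A modest move in this assay downward is therefore expected, with wide uncertainty.

The expected step is a 1.8-fold lower number from compound 3 to compound 4 (0.26 log units; within the scatter). Compound 4 is estimated at 9000 nM, with a range from 3000 nM to 27000 nM.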

Compound 4, half-maximal inhibitory concentration: 7050 nM
Compound 4: the middle estimate sits 1.3-fold (0.11 log units) above what was measured, and the stated range covers the measured number.
By their numbers in this assay, from the lowest: compound 1; then compound 4; then compounds 3 and 2 (each within the scatter of the next).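

On the aromatic nitrogen of the shared core, the aryl group does register in this assay: a 2.3-fold lower number from compound 3 to compound 4 (0.37 log units; beyond the scatter) is a modest step beyond the scatter, although 3-fluorophenyl and 4-fluorophenyl have the same atoms and differ only in where the fluorine sits. Compound 4 also separates from the 2-(trifluoromethyl)phenyl compound, with a 2.8-fold lower number from compound 2 to compound 4 (0.45 log units; beyond the scatter), whereas a 1.2-fold lower number from compound 2 to compound 3 (0.08 log units; within the scatter) had shown no resolved difference at this position. With 4-fluorophenyl held constant, a 3.0-fold higher number from compound 1 to compound 4 (0.48 log units; beyond the scatter) isolates the effect of the differently joined core, showing that the core change on its own also moves the number in this assay.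

No measurement shown here accounts for any of these steps. From the compounds shown here alone, it remains open whether a plain phenyl, a chlorophenyl or a methoxyphenyl on the same nitrogen would fall with compound 4 or with compound 3, and whether the 3-fluorophenyl and 2-(trifluoromethyl)phenyl groups would keep their place relative to 4-fluorophenyl on the core of compound 1.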